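The source may report more compounds than this note shows. Statements on the series, on what has been measured and on what is new or still open speak of the compounds shown alone.

Measured compounds:
- compound 1, `Nc1ccn(C2OC(CO)C(Br)C2O)c(=O)n1`: 0.05 ug/mL in a functional assay on P815 cells (Mus musculus) for antiproliferative activity; a lower number here means a stronger inhibitor, a higher number a weaker inhibitor
- compound 2, `Nc1ccn([C@@H]2O[C@H](CO)[C@H](F)[C@H]2O)c(=O)n1`: 21 ug/mL in this assay

Compound 1 stands at the lowest of the two numbers, and compound 2 sits far above it, well beyond the scatter. Compound 3, `Nc1ccn(C2OC(CO)C(Cl)C2O)c(=O)n1`, has not been measured. It differs from compound 1 in one place: chloro in place of bromo on a saturated ring carbon. For the measured compounds named here, compound 2 carries a fluoro group at that same saturated ring carbon and gives the much higher number, but no step from compound 1 to compound 2 has been worked out, so only the two values themselves are known. With only these two points to go on, a modest loss is expected for compound 3 in this assay, a step of a 4.0-fold higher number from compound 1 to compound 3 (0.60 log units; beyond the scatter) towards a higher number. The estimate for compound 3 is 0.2 ug/mL, within a range from 0.03 ug/mL to 2 ug/mL.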

Compound 3, concentration for 50% inhibition: 0.8 ug/mL
Beside the measured number, compound 3's estimate is 4.0-fold (0.60 log units) below it; low and high end bracket the measured number.
By their numbers in this assay, from the lowest: compound 1; then compound 3; then compound 2.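

In this assay, this saturated ring carbon proves highly sensitive to the halogen it carries: chloro in place of bromo gives a 16-fold higher number from compound 1 to compound 3 (1.20 log units; beyond the scatter) and so a much weaker inhibitor. For the compounds shown here, the exchange swaps one heavy atom for another, with no change in the count of hydrogen-bond donors or acceptors and no net charge, and it is the first direct measure of what a change at this position alone does. Going by these compounds alone, nothing available here explains why so small an exchange moves the number so far.

The compounds shown leave open how an iodo group, an amine or a methoxy group on this same carbon would behave. They also leave open what the arrangement in space at this carbon contributes, as the structures of compound 1 and compound 3 do not specify it.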